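The source may report more compounds than this note shows. Statements on the series, on what has been measured and on what is new or still open speak of the compounds shown alone.

Compound 1 `O=C(CCc1ccc(O)cc1)C[C@@H]1O[C@@H](c2ccc(O)cc2)[C@H]2[C@@H]1[C@H](c1ccc(O)cc1)O[C@H]2CC(=O)CCc1ccc(O)cc1` and compound 2 `COc1cc([C@@H]2O[C@@H](CC(=O)CCc3ccc(O)cc3)[C@@H]3[C@H]2[C@H](CC(=O)CCc2ccc(O)cc2)O[C@H]3c2ccc(O)c(OC)c2)ccc1O` share one core. In a functional assay on BV-2 cells (Mus musculus), with stated times of 2 h and 24 h, tested at 10 uM (a lower number here means a stronger effect, a higher number a weaker effect of the compound at the concentration tested), compound 2 gives 85%, and compound 1 gives 87.8%; the two numbers lie within the scatter of each other, so neither can be placed above the other. Compound 3 `COc1cc([C@@H]2O[C@@H](CC(=O)CCc3ccc(O)cc3)[C@@H]3[C@H]2[C@H](CC(=O)CCc2ccc(O)cc2)O[C@H]3c2ccc(O)cc2)ccc1O` has not yet been measured. It differs from compound 2 in one place: hydrogen in place of methoxy on an aromatic carbon. Since the two measured compounds give similar numbers, the step is expected to be a number 1 percentage points higher from compound 2 to compound 3 (within the scatter), not beyond the scatter in either direction. Compound 3 is therefore expected to give 86% in this assay, between 76% and 96%.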

Compound 3, a percentage reported as activity, at one concentration (the size of the read-out at that concentration, not a potency): 86.8%
The estimate for compound 3 lay 0.8 percentage points below the measured number, and the stated range covers the measured number.
By their numbers in this assay, from the lowest: compounds 2, 3 and 1 (each within the scatter of the next).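

Going by these compounds alone, compound 3 carries one 4-hydroxy-3-methoxyphenyl and one 4-hydroxyphenyl, so it supplies the single steps that compounds 1 and 2 could not show. In this assay, removing one methoxy gives a number 1.8 percentage points higher from compound 2 to compound 3 (within the scatter), and adding one gives a number 1 percentage points lower from compound 1 to compound 3 (within the scatter), so on this aromatic carbon, ortho to a hydroxy group, neither step can be told from the scatter. Nothing at hand explains this result. Going by these compounds, whether an amine or a carboxylic acid on this carbon would give a number beyond the scatter stays open. So does the outcome of replacing the hydroxy group itself.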